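A few compounds are considered here, and "the series" means these few. Any claim that something is new, unique, unknown or untested is made for them only; others in the source may bear on it.

Two compounds have been measured so far in a functional assay on U-373MG ATCC cells (Homo sapiens) for cytotoxicity, read by MTT assay, with a stated time of 72 h (a higher number here means a weaker inhibitor, a lower number a stronger inhibitor), for comparison
- compound 1 `COc1cc(/C=C/C=O)cc(OC)c1OC/C=C(\C)CCC=C(C)C` gives 8000 nM 
- compound 2 `COc1cc(/C=C/C=O)cc(OC)c1OCC=C(C)C` gives 30000 nM 

Compound 1 holds the lower number of the two. Compound 3 `COc1cc(/C=C/C=O)ccc1OC/C=C(\C)CCC=C(C)C` departs from compound 1 by one change, hydrogen in place of methoxy on an aromatic carbon and nothing else. Within the data shown here, the only measured step is a 3.8-fold higher number from compound 1 to compound 2 (0.57 log units; beyond the scatter) and it lies elsewhere in the molecule, so it shows only that a single change here can be modest in size. Among the measured compounds shown here, no measured step touches the methoxy group, so the expectation in this assay is a step within the scatter, with no firm direction. The estimated step is a 1.3-fold higher number from compound 1 to compound 3 (0.10 log units; within the scatter) and remains uncertain. Compound 3 is expected at 10000 nM with an estimated range of 4000 nM to 25000 nM in this measurement.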

Compound 3, half-maximal inhibitory concentration: 7000 nM
Compound 3: middle estimate off by 1.4-fold (0.15 log units), on the high side; the measured number falls inside the stated range.
By their numbers in this assay, from the lowest: compounds 3 and 1 (each within the scatter of the next); then compound 2.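

With hydrogen in place of methoxy on this aromatic carbon, the result in this assay is a step within the scatter (a 1.1-fold lower number from compound 1 to compound 3 (0.06 log units; within the scatter)), so this methoxy group, ortho to a large group, is not required to hold the number at the level of compound 1. Among these compounds, the only earlier step, on the chain (a 3.8-fold higher number from compound 1 to compound 2 (0.57 log units; beyond the scatter)), lay beyond the scatter, so a single change does not always register. Nothing available explains this outcome. The compounds shown leave open whether a hydroxyl, an amine or a fluorine at this carbon would shift the number. They also leave open whether the remaining methoxy group, meta to this position, could be replaced by hydrogen too.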